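Cytotoxicity of chloroquinoline amidines with varied basic side chains

The source may report more compounds than this note shows. Statements on the series, on what has been measured and on what is new or still open speak of the compounds shown alone.

Measured compounds:
compound 1 `CCN(CC)CCCCCN/C(C)=N\c1ccnc2cc(Cl)ccc12`, 12.5 ug/mL
compound 2 `C/C(=N/c1ccnc2cc(Cl)ccc12)NCCCCN1CCCCC1`, 9.81 ug/mL
compound 3 `CC(C)/C(=N/c1ccnc2cc(Cl)ccc12)NCCCN1CCCCC1`, > 24.2 ug/mL

Three amidines on a shared chloroquinoline core were tested in an ADME assay on HepG2 cells (Homo sapiens) for cytotoxicity, read by MTT assay, with a stated time of 48 h; a lower number here means a stronger inhibitor, a higher number a weaker inhibitor. Compound 2 gives 9.81 ug/mL, and compound 1 gives 12.5 ug/mL. The step of a 1.3-fold higher number from compound 2 to compound 1 (0.11 log units; within the scatter) corresponds to the change ((diethylamino)methyl in place of piperidin-1-yl on a saturated chain carbon, four bonds along the chain from an amine nitrogen), so the two values lie together. Compound 3 reaches only the limit of this assay, > 24.2 ug/mL; this is the limit of > 24.2 ug/mL in this assay, at which 1 of the 3 values shown sits. How the core of compound 3 differs from that of compound 2 is not broken down here.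

Compound 4 `CCN(CC)CCCCN/C(=N\c1ccnc2cc(Cl)ccc12)C(C)C` has not yet been measured. It differs from compound 3 by (diethylamino)methyl in place of piperidin-1-yl on a saturated chain carbon, three bonds along the chain from an amine nitrogen, the same kind of change as that from compound 2 to compound 1, though here the place lies three bonds along the chain from an amine nitrogen rather than four. Since that earlier step stayed within the scatter, compound 4 is expected to stay close to compound 3, with a step that the limit leaves unreadable from compound 3 to compound 4, and compound 4 is estimated at 28 ug/mL, most likely again as a limit.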

Compound 4, half-maximal inhibitory concentration: 5.01 ug/mL
Beside the measured number, compound 4's estimate is 5.6-fold (0.75 log units) above it, outside the stated range (below it).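

In this assay, putting (diethylamino)methyl in place of piperidin-1-yl gave an at least 4.8-fold lower number from compound 3 to compound 4 (0.68 log units; beyond the scatter), so the change did not carry over unaltered from one core to the other: the same change on two cores in this assay, a 1.3-fold higher number (0.11 log units; within the scatter) from compound 2 to compound 1 and an at least 4.8-fold lower number (0.68 log units; beyond the scatter) from compound 3 to compound 4, at least 6.1-fold (0.78 log units) apart, beyond the scatter of two such steps

The value of compound 3, > 24.2 ug/mL, is a limit of the assay and not a number: the limit of > 24.2 ug/mL in this assay, at which 1 of the 4 values shown sits.

These two pairs show that the outcome of this change depends on the compounds that carry it, but they do not show which feature of the two cores accounts for the gap, and they set no rule for the wider series.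

The compounds shown leave open how the change would read on a core that differs from the core of compound 2 in only one place, for instance one pairing the isopropyl group of compound 3 with a longer chain. They also leave open whether other cyclic amines, such as pyrrolidine or morpholine, would follow piperidin-1-yl or (diethylamino)methyl on either core.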